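Bromo for Chloro on a Shared Pyrazole Acid Core

The compounds below may be only part of what the source reports. "The series", "measured", "known", "first", "only" and "open" are said of these compounds alone.

Four compounds built on one shared core are compared here in an ADME assay on HaCaT cells (Homo sapiens) for inhibition, read by sulforhodamine B assay, with a stated time of 48 h; a higher number here means a weaker inhibitor of growth, a lower number a stronger inhibitor of growth. Compound 1 is `CC(C)(C)NCc1c(C(=O)O)nn(-c2ccccc2)c1-c1ccc(Cl)cc1`, compound 2 is `CC(C)(C)NCc1c(C(=O)O)nn(-c2ccccc2)c1-c1ccc(Br)cc1`, compound 3 is `CC(C)(C)NCc1c(C(=O)O)nn(-c2ccc(Cl)cc2)c1-c1ccc(Cl)cc1`, and the unmeasured compound 4 is `CC(C)(C)NCc1c(C(=O)O)nn(-c2ccc(Cl)cc2)c1-c1ccc(Br)cc1`.

In this assay compound 1 gives > 652000 nM, which is a limit of the assay rather than a number. One of the three values shown sits at the limit of > 652000 nM in this assay, at which 1 of the 3 values shown sits. Compound 2 gives 366000 nM, and compound 3 gives 87500 nM.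

Compound 2 differs from compound 1 by bromo in place of chloro on an aromatic carbon. That change gave an at least 1.7-fold lower number from compound 1 to compound 2 (0.25 log units; that floor lies within the scatter). Compound 3 differs from compound 1 by chloro in place of hydrogen on an aromatic carbon, and that change gave an at least 7.4-fold lower number from compound 1 to compound 3 (0.87 log units; beyond the scatter), so compound 3 stands as the lowest of the two numbers, with compound 2 the nearest.

Compound 4 differs from compound 3 by bromo in place of chloro on an aromatic carbon. The place lines for this change and for the change from compound 1 to compound 2 read the same word for word, so it is the same change made on a different core, and how the two cores differ is given above under the difference between compound 1 and compound 3. Measured once, the change moved the number only by a step whose floor lies within the scatter, so the step to compound 4 is expected to be small.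

For compound 4 the estimated step is a 1.5-fold lower number from compound 3 to compound 4 (0.16 log units; within the scatter), resting on the earlier step from compound 1 to compound 2. Compound 4 is therefore expected to give about 60000 nM in this assay, with a range from 25000 nM to 160000 nM.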

Compound 4, concentration for 50% growth inhibition: > 542000 nM
Compound 4: a limit, no number (the forecaster's own chance of this, stated with the estimate: 5%); middle value at least 9.0-fold (0.95 log units) away from the limit.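

In this assay, bromo in place of chloro on an aromatic carbon gave an at least 6.1-fold higher number from compound 3 to compound 4 (0.79 log units; beyond the scatter), so this change did not carry over with the same result from the core of compound 1 to the core of compound 3: the same change on two cores in this assay, an at least 1.7-fold lower number (0.25 log units; that floor lies within the scatter) from compound 1 to compound 2 and an at least 6.1-fold higher number (0.79 log units; beyond the scatter) from compound 3 to compound 4, at least 11-fold (1.04 log units) apart, beyond the scatter of two such steps

Chloro in place of hydrogen on an aromatic carbon behaved the same way, giving an at least 1.4-fold higher number from compound 2 to compound 4 (0.17 log units; that floor lies within the scatter), so its result on the core of compound 1 did not hold on the core of compound 2: the same change on two cores in this assay, an at least 7.4-fold lower number (0.87 log units; beyond the scatter) from compound 1 to compound 3 and an at least 1.4-fold higher number (0.17 log units; that floor lies within the scatter) from compound 2 to compound 4, at least 11-fold (1.04 log units) apart, beyond the scatter of two such steps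

For compound 1 and compound 4 the assay gives limits and not numbers, so the true size of each of these steps stays unknown, and these four compounds do not show why the steps differ between cores.

Still open, as far as these compounds go, is whether other groups in the same place, such as fluoro, iodo or methyl, would also give results that depend on the core. Also open, from the compounds shown here alone, is whether an ester or an amide in place of the carboxylic acid would give measured numbers for all four compounds instead of limits for two of them.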